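A Thiol Amide Gains an Ethoxycarbonyl Group

The source may report more compounds than this note shows. Statements on the series, on what has been measured and on what is new or still open speak of the compounds shown alone.

Values so far in a functional assay on microsomes from liver (Rattus norvegicus) for inhibition, read by spectrophotometry, with a stated time of 45 min (on this read-out higher numbers stand for weaker inhibition and lower numbers for stronger inhibition), are as follows
- compound 1 `CCOC(=O)C(CS)NC(=O)c1cc(C(C)(C)C)c(O)c(C(C)(C)C)c1` gives 200000 nM
- compound 2 `Cc1c(C)c2c(c(C)c1O)CCC(C)(C(=O)NCCS)O2` gives 1600 nM

Compound 2 stands lowest of the two at 1600 nM and compound 1 lies higher at 200000 nM on the same scale. The gap between these two lies beyond the scatter. Compound 3 `CCOC(=O)C(CS)NC(=O)C1(C)CCc2c(C)c(O)c(C)c(C)c2O1` keeps the core of compound 2 and alters only its amide side chain. The change is ethoxycarbonyl in place of hydrogen on a saturated chain carbon bound to an amide-type nitrogen and a saturated chain carbon with ethoxycarbonyl in place of hydrogen on a saturated chain carbon bound to an amide-type nitrogen and a saturated chain carbon. The 2-sulfanylethyl chain thus becomes 1-(ethoxycarbonyl)-2-sulfanylethyl. Within the data shown here, compound 1 already carries this longer chain on a different core, but no measured pair separates the effect of the chain from that of the core. In this assay only a small move toward a higher number is therefore expected, with no clear departure from the scatter. The estimated change is a 1.9-fold higher number from compound 2 to compound 3 (0.27 log units; within the scatter) and it rests on the shared core. Compound 3 is expected at 3000 nM with an estimated range from 700 nM to 13000 nM in this measurement.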

Compound 3, half-maximal inhibitory concentration: 3000 nM
The estimate for compound 3 equals the measured number at the digits printed; low and high end bracket the measured number.
By their numbers in this assay, from the lowest: compounds 2 and 3 (each within the scatter of the next); then compound 1.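

In this assay, ethoxycarbonyl in place of hydrogen on a saturated chain carbon bound to an amide-type nitrogen and a saturated chain carbon gives a 1.9-fold higher number from compound 2 to compound 3 (0.27 log units; within the scatter), so this read-out does not tell the 2-sulfanylethyl and 1-(ethoxycarbonyl)-2-sulfanylethyl chains apart on the shared core. Among these compounds, this is the first pair in which the chain alone changes, whereas compound 1 and compound 2 differ in both chain and core and could not show what this position does by itself. On the core of compound 2, then, the added ethoxycarbonyl group does not reproduce the much higher number of compound 1, 200000 nM, and nothing shown gives a measured reason for this result.

From the compounds shown here alone, it remains open whether a carboxylic acid, an amide or a longer ester chain in place of the ethoxycarbonyl group on this carbon would also stay within the scatter of compound 2. Going by these compounds, it also remains open how the 2-sulfanylethyl chain would read on the core of compound 1, and so how much of that compound's number belongs to its core.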